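Extending the amide chain of compound 3

The source may report more compounds than this note shows. Statements on the series, on what has been measured and on what is new or still open speak of the compounds shown alone.

Measured so far in a functional assay on cells (Homo sapiens) for antiproliferative activity, read by sulforhodamine B assay, with a stated time of 48 h; a lower number here means a stronger inhibitor, a higher number a weaker inhibitor:
Compound 1 `CCCCCCCCNC(=O)[C@@H]1CSC(c2cc(OC)c(OC)c(OC)c2)N1`: 17100 nM
Compound 2 `CCCCCCCCCCCCCCNC(=O)[C@@H]1CSC(c2cc(OC)c(OC)c(OC)c2)N1`: 2000 nM
Compound 3 `CCCCCCCCCCCCCCCNC(=O)[C@@H]1CSC(c2ccc(NC(C)=O)cc2)N1`: 1600 nM

Compound 3 gives 1600 nM and compound 2 gives 2000 nM, which places the two within the scatter of each other. Compound 1 stands apart from compound 3, beyond the scatter.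

Compound 4 `CCCCCCCCCCCCCCCCCCNC(=O)[C@@H]1CSC(c2ccc(NC(C)=O)cc2)N1` differs from compound 3 by a single change in the chain: propyl in place of hydrogen on a saturated chain carbon, ten or more bonds along the chain from an amide-type nitrogen. Within the data shown here, only one measured step bears on this change: an 8.6-fold lower number from compound 1 to compound 2 (0.93 log units; beyond the scatter), a modest step beyond the scatter, in which hexyl takes the place of hydrogen on the chain. The guidance it offers is limited. It involves a larger addition to a shorter chain, and compound 1 and compound 2 carry a different aromatic group from compound 3. A smaller shift in the same direction is therefore expected in this assay, probably not beyond the scatter. The expected step is a 1.2-fold lower number from compound 3 to compound 4 (0.09 log units; within the scatter). Compound 4 is estimated at 1300 nM, with an expected range of 500 nM to 3500 nM.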

Compound 4, half-maximal inhibitory concentration: 22300 nM
The estimate for compound 4 lay 17-fold (1.23 log units) below the measured number, and the stated range ends below it.
By their numbers in this assay, from the lowest: compounds 3 and 2 (each within the scatter of the next); then compounds 1 and 4 (each within the scatter of the next).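

In this assay, adding propyl on a saturated chain carbon gives a change in the opposite direction to the earlier hexyl addition: a 14-fold higher number from compound 3 to compound 4 (1.14 log units; beyond the scatter) here, against an 8.6-fold lower number from compound 1 to compound 2 (0.93 log units; beyond the scatter) in the earlier pair. Chain extension therefore does not have a single direction across these compounds, although the two steps start from different chains and carry different aromatic groups. No available evidence explains the reversal.

The compounds shown leave open whether the rise appears abruptly or gradually across chains between those of compound 3 and compound 4, and whether the same addition would raise the number with the aromatic group of compound 2. They also do not show how an amine or a carboxylic acid at the chain end would behave.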